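Swapping the outer ring of a potent biaryl sulfonamide

The source may hold more compounds than are shown below. What is called first, only, known or untested is meant among the compounds shown, and "the series" means these compounds.

Compound 3, `COc1ccc(N2C[C@@H](C)N[C@@H](C)C2)cc1NS(=O)(=O)c1ccc(-c2cc(Cl)ccc2F)cc1`, has the lowest number of the three measured compounds in a functional assay for agonist activity at growth hormone secretagogue receptor type 1 (Homo sapiens), read by FLIPR (a higher number here means that more compound is needed for the effect, a lower number that less compound is needed), with 0.501 nM. Compound 1, `COc1ccc(N2C[C@@H](C)N[C@@H](C)C2)cc1NS(=O)(=O)c1ccc(-c2ccccc2)cc1`, gives 6.31 nM, and compound 2, `COc1cccc(-c2ccc(S(=O)(=O)Nc3cc(N4C[C@@H](C)N[C@@H](C)C4)ccc3OC)cc2)c1`, gives 2 nM. Compound 4, `COc1ccc(N2C[C@@H](C)N[C@@H](C)C2)cc1NS(=O)(=O)c1ccc(-c2ccncc2)cc1`, differs from compound 3 in one place: pyridin-4-yl in place of 5-chloro-2-fluorophenyl on an aromatic carbon. Going by the values given here, the steps that bear on this change are a 13-fold lower number from compound 1 to compound 3 (1.10 log units; beyond the scatter) and a 4.0-fold lower number from compound 2 to compound 3 (0.60 log units; beyond the scatter), both of which show that the 5-chloro-2-fluorophenyl group gives the lowest number of the three outer rings. Replacing it with pyridin-4-yl removes that group, so a higher number for compound 4 is expected, of roughly the size seen with a 13-fold lower number from compound 1 to compound 3 (1.10 log units; beyond the scatter). The estimate for compound 4 is 8 nM, with a range of 2 nM to 32 nM, an expected step of a 16-fold higher number from compound 3 to compound 4 (1.20 log units; beyond the scatter).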

Compound 4, half-maximal effective concentration: 316 nM
Estimate against measurement, compound 4: 40-fold (1.60 log units) below, and the stated range ends below it.
By their numbers in this assay, from the lowest: compound 3; then compound 2; then compound 1; then compound 4.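

In this assay, this position proves far less forgiving than the three carbon-only outer rings suggested, since pyridin-4-yl sits well above all of them (a 630-fold higher number from compound 3 to compound 4 (2.80 log units; beyond the scatter); a 160-fold higher number from compound 2 to compound 4 (2.20 log units; beyond the scatter); a 50-fold higher number from compound 1 to compound 4 (1.70 log units; beyond the scatter)). The step from plain phenyl matters most: with no chlorine, fluorine or methoxy involved, one ring nitrogen in place of a ring carbon goes with a large rise. No measurement shown explains this rise. As far as these compounds go, whether an outer ring carrying an amine or a carboxylic acid would follow pyridin-4-yl or the carbon-only rings remains open.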